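A few compounds are considered here, and "the series" means these few. Any claim that something is new, unique, unknown or untested is made for them only; others in the source may bear on it.

Measured in a physicochemical assay for solubility, read by spectrophotometry, in phosphate buffer, measured as kinetic solubility, with a stated time of 18 h, at pH 7.4; a higher number here means a more soluble compound, a lower number a less soluble compound:
compound 1 `COc1ccc(-c2nc3ccccc3o2)cc1NC(=O)c1cc([N+](=O)[O-])ccc1Cl`: 90 nM
compound 2 `COc1ccc(-c2nc3ccccc3s2)cc1NC(=O)c1cc([N+](=O)[O-])c(N2CCC(C(=O)O)CC2)cc1Cl`: 210 nM
compound 3 `COc1ccc(-c2nc3ccccc3s2)cc1NC(=O)c1cc([N+](=O)[O-])c(N2CCN(C)CC2)cc1Cl`: 500 nM

Compound 3, at 500 nM, holds the highest of the three numbers. Closest to it is compound 2 at 210 nM, and furthest is compound 1 at 90 nM.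

Compound 4 `COC(=O)C1CCN(c2cc(Cl)c(C(=O)Nc3cc(-c4nc5ccccc5s4)ccc3OC)cc2[N+](=O)[O-])CC1` has not yet been measured. It differs from compound 3 as follows: 4-(methoxycarbonyl)piperidin-1-yl in place of 4-methylpiperazin-1-yl on an aromatic carbon. In short, 4-(methoxycarbonyl)piperidin-1-yl stands in place of 4-methylpiperazin-1-yl on an aromatic carbon, ortho to a nitro group.

Going by the values given here, only one measured step bears on this change: a 2.4-fold higher number from compound 2 to compound 3 (0.38 log units; beyond the scatter), a modest step, with 4-methylpiperazin-1-yl in place of 4-carboxypiperidin-1-yl at the same position. Compound 4 shares its six-membered non-aromatic ring with 1 hetero atom with compound 2, so a move back down in this assay, of about the size of that step or somewhat larger, is expected. Among the compounds with values here, no measured pair isolates the methoxycarbonyl group itself, so the size remains uncertain and the range is wide.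

The expected change is a 3.3-fold lower number from compound 3 to compound 4 (0.52 log units; beyond the scatter). For compound 4 the estimated value is 150 nM, with an expected range from 40 nM to 500 nM.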

Compound 4, solubility: 170 nM
Beside the measured number, compound 4's estimate is 1.1-fold (0.05 log units) below it; measured number inside the range.
By their numbers in this assay, from the lowest: compounds 1, 4 and 2 (each within the scatter of the next, the first and the last beyond it); then compound 3.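

In this assay, putting 4-(methoxycarbonyl)piperidin-1-yl in place of 4-methylpiperazin-1-yl on the aromatic carbon ortho to a nitro group gives a 2.9-fold lower number from compound 3 to compound 4 (0.47 log units; beyond the scatter) and so a step beyond the scatter, the second such step seen at this position. Placing methyl in place of hydrogen on the oxygen of the 4-carboxypiperidin-1-yl group gives a 1.2-fold lower number from compound 2 to compound 4 (0.09 log units; within the scatter) and so stays within the scatter, which the earlier compounds could not show, since none isolated this change. At this position, then, compound 2 and compound 4, which both carry a six-membered non-aromatic ring with 1 hetero atom, cannot be told apart, while compound 3, with 2 hetero atoms in that ring, stands beyond the scatter from both.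

These three compounds do not separate the ring from its substituent, since the ring and the substituent change together between compound 3 and the other two. A piperidine ring carrying an amine, or a piperazine ring carrying a methoxycarbonyl group, would pull the two apart. Nothing measured here gives a reason for these steps.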